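The compounds below may be only part of what the source reports. "The series", "measured", "known", "first", "only" and "open" are said of these compounds alone.

Working notes on the series in an assay on isolated protein for inhibition of histone deacetylase 11 (Homo sapiens), read by mobility shift assay; on this read-out higher numbers stand for weaker inhibition and lower numbers for stronger inhibition. The shared core carries a hydroxamic acid and a pentafluorophenylsulfonamide; the compounds differ in the benzyl-type arm on the sulfonamide nitrogen and in the fluorine count of the sulfonyl ring. Compound 1 `O=C(NO)c1ccc(CN(Cc2ccccc2)S(=O)(=O)c2c(F)c(F)c(F)c(F)c2F)cc1` gives 122 nM in this assay. Compound 2 `O=C(NO)c1ccc(CN(Cc2ccc(F)cc2)S(=O)(=O)c2c(F)c(F)c(F)c(F)c2F)cc1` gives 787 nM in this assay. For compound 3 `O=C(NO)c1ccc(CN(Cc2ccncc2)S(=O)(=O)c2c(F)c(F)c(F)c(F)c2F)cc1` this assay reports only a limit, > 1000 nM. The change hydrogen in place of fluoro on an aromatic carbon brings a 6.5-fold lower number from compound 2 to compound 1 (0.81 log units; beyond the scatter). The change pyridin-4-yl in place of 4-fluorophenyl on a saturated chain carbon bound to a sulfonamide nitrogen brings an at least 1.2-fold higher number from compound 2 to compound 3 (0.10 log units; that floor lies within the scatter), and from compound 1 the arm change gives an at least 8.1-fold higher number from compound 1 to compound 3 (0.91 log units; beyond the scatter), where the floor is set by the limit of > 1000 nM in this assay, at which 1 of the 3 values shown sits.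

Compound 4 `O=C(NO)c1ccc(CN(Cc2ccncc2)S(=O)(=O)c2cc(F)c(F)c(F)c2F)cc1` is not yet measured. It arises from compound 3 by hydrogen in place of fluoro on an aromatic carbon. This is the same kind of change as the step from compound 2 to compound 1, but the place differs: there the position was para to a large group, here it is ortho to a fluoro group, ortho to a large group, meta to two fluoro groups and para to a fluoro group. The change sits on a different ring, so the earlier step is a weak guide; the expected step is a step that the limit leaves unreadable from compound 3 to compound 4, resting on the limit for compound 3 > 1000 nM. The estimate for compound 4 is 1500 nM, range 400 nM to 6000 nM, with a fair chance that this assay again reports only a limit.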

Compound 4, half-maximal inhibitory concentration: 472 nM
The estimate for compound 4 lay 3.2-fold (0.50 log units) above the measured number, within the range that was stated.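

In this assay hydrogen in place of fluoro on the sulfonyl ring gives an at least 2.1-fold lower number from compound 3 to compound 4 (0.32 log units; beyond the scatter) and the number falls in both pairs that carry this change, which compare as follows: the same change on two cores in this assay, a 6.5-fold lower number (0.81 log units; beyond the scatter) from compound 2 to compound 1 and an at least 2.1-fold lower number (0.32 log units; beyond the scatter) from compound 3 to compound 4; the limit leaves it open whether they differ. The direction is shared, but the earlier step lies on the benzyl-type arm and the new one on the sulfonyl ring, so the two pairs do not show one position being carried from one core to another. The new step is only a floor, so its true size and any gap from the earlier step cannot be read, and the series holds one such limit: the limit of > 1000 nM in this assay, at which 1 of the 4 values shown sits.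

Still open, on these data alone, is how the 2,3,4,5-tetrafluorophenyl group behaves with the phenyl and 4-fluorophenyl arms of compound 1 and compound 2. Also open, as far as these compounds go, is whether a chloro or methoxy group at the same place on the sulfonyl ring, or an amine or carboxylic acid on the arm, would shift the number in the same direction.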